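The source may report more compounds than this note shows. Statements on the series, on what has been measured and on what is new or still open speak of the compounds shown alone.

In a functional assay on J82 cells (Homo sapiens) for cytotoxicity, read by colorimetric assay and MTT assay (a lower number here means a stronger inhibitor, a higher number a weaker inhibitor), compound 1 `Oc1ccc(-c2cc3c(O)cc(O)cc3nc2O)cc1` gives 10000 nM and compound 2 `Cn1c(=O)c(-c2ccc(O)cc2)cc2c(O)cc(O)cc21` gives 10000 nM. Compound 3 `COc1ccc(-c2cc3c(OC)cc(OC)cc3n(C)/c2=N\Nc2ccccc2)cc1` stands level with both at 10000 nM, so the three compounds show no separation. Compound 4 `COc1ccc(-c2cc3c(OC)cc(OC)cc3n(C)/c2=N\Nc2ccccn2)cc1` differs from compound 3 in one place: pyridin-2-yl in place of phenyl on an amine nitrogen, with pyridin-2-yl in place of phenyl on an amine nitrogen. Going by the values given here, no measured pair shows what a single structural change does here, so any forecast rests on thin evidence. The size of the ring stays the same, and a modest shift toward stronger inhibition is expected, possibly none beyond the scatter. The estimated change is a 1.7-fold lower number from compound 3 to compound 4 (0.22 log units; within the scatter). For compound 4, the expected value is 6000 nM, within an estimated range of 1200 nM to 14000 nM.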

Compound 4, half-maximal inhibitory concentration: 10000 nM
Compound 4: middle estimate off by 1.7-fold (0.22 log units), on the low side; the measured number falls inside the stated range.
By their numbers in this assay, from the lowest: compounds 1, 2, 3 and 4 (each within the scatter of the next).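

Going by these compounds alone, putting pyridin-2-yl in place of phenyl on an amine nitrogen gives the first single-place comparison in this assay, with no change at the digits printed from compound 3 to compound 4 (within the scatter). At this position, swapping one ring carbon for nitrogen, which adds one hydrogen-bond acceptor by count, leaves the reading unmoved. No supporting measurement is available to explain this result.

Going by these compounds, it remains open whether a different group at this place, such as a benzyl group or a ring carrying a carboxylic acid, would give a different number. On these data alone, the effect of changes elsewhere on the shared core also remains open.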